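A few compounds are considered here, and "the series" means these few. Any claim that something is new, unique, unknown or untested is made for them only; others in the source may bear on it.

In a functional assay on HCT-116 cells (Homo sapiens) for cytotoxicity, read by sulforhodamine B assay, with a stated time of 48 h (a lower number here means that less compound is tolerated, a higher number that more compound is tolerated), compound 1 `ClCc1ccccc1Cn1cnc2c(Cl)nc(Cl)nc21` gives 750 nM. Compound 2 `ClCc1cccc(Cn2cnc3c(Cl)nc(Cl)nc32)c1` gives 5880 nM in this assay, a higher number than compound 1; the difference between the two cores is not broken down here. Compound 3 `Nc1nc(Cl)c2ncn(Cc3ccccc3CCl)c2n1` reaches only a limit of the assay in this assay, > 100000 nM. This value is the limit of > 100000 nM in this assay, at which 1 of the 3 values shown sits. The step of an at least 130-fold higher number from compound 1 to compound 3 (2.12 log units; beyond the scatter) follows the change (amino in place of chloro on an aromatic carbon). Compound 4 `Nc1nc(Cl)c2ncn(Cc3cccc(CCl)c3)c2n1` has not yet been measured in this assay; it carries the same change against compound 2, namely (amino in place of chloro on an aromatic carbon), and the surroundings of the place are the same in both pairs. Among the compounds with values here, the step from compound 2 to compound 4 is expected to be a 34-fold higher number from compound 2 to compound 4 (1.53 log units; beyond the scatter), a step of about the same size as the measured one, because an at least 130-fold higher number from compound 1 to compound 3 (2.12 log units; beyond the scatter) is the only step of this kind seen so far. Since compound 2 already sits at 5880 nM, compound 4 is expected to give 200000 nM, within a range from 60000 nM to 1000000 nM.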

Compound 4, concentration lethal to 50% of the cells: 75900 nM
Estimate against measurement, compound 4: 2.6-fold (0.42 log units) above; low and high end bracket the measured number.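

In this assay, amino in place of chloro gives a higher number on both cores, with a 13-fold higher number from compound 2 to compound 4 (1.11 log units; beyond the scatter), so the direction of the change carries over from the core of compound 1 to the core of compound 2, though two pairs cannot make a general rule. The size of the step does not carry over, and a step measured on one core is only a rough guide on the other: the same change on two cores in this assay, an at least 130-fold higher number (2.12 log units; beyond the scatter) from compound 1 to compound 3 and a 13-fold higher number (1.11 log units; beyond the scatter) from compound 2 to compound 4, at least 10-fold (1.01 log units) apart, beyond the scatter of two such steps. Going by these compounds, compound 3 stands at a limit of the assay and not at a number, so the full size of its step stays unknown: the limit of > 100000 nM in this assay, at which 1 of the 4 values shown sits.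

The compounds shown leave open why the two cores respond to different extents, since the difference between them is not broken down here. They also leave open what a different group at this place would do, such as a methylamino group or a methoxy group, and whether such a group would give steps that carry over more evenly between the two cores.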